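A few compounds are considered here, and "the series" means these few. Any claim that something is new, unique, unknown or untested is made for them only; others in the source may bear on it.

Working notes on the series. Compound 1 `CCCCc1ccc2[nH]c(-c3ccc(OC)cc3)c(C=O)c2c1` gives 6.7 nM in a functional assay on MDA-MB-231 cells (Homo sapiens) for antiproliferative activity, with a stated time of 4 days; a lower number here means a stronger inhibitor, a higher number a weaker inhibitor. Within the data shown here, compound 2 `CCCCc1ccc2[nH]c(-c3ccc(OC)cc3)c(/C=N/NC(=O)c3ccccc3)c2c1` gives 32 nM, the middle of the three numbers so far, and compound 3 `CCCCc1ccc2[nH]c(-c3ccc(C(F)(F)F)cc3)c(/C=N/NC(=O)c3ccccc3)c2c1` gives 300 nM, the highest.

The unmeasured compound 4 `CCCCc1ccc2[nH]c(-c3ccc(OC)cc3)c(/C=N/NC(=O)c3cccc(O)c3)c2c1` follows from compound 2 by hydroxy in place of hydrogen on an aromatic carbon. This is hydroxy in place of hydrogen on an aromatic carbon, turning benzoyl into (3-hydroxyphenyl)carbonyl.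

Among the measured compounds shown here, only one measured step bears on this, and only indirectly: a 9.4-fold higher number from compound 2 to compound 3 (0.97 log units; beyond the scatter), with trifluoromethyl in place of methoxy. That step is modest and beyond the scatter, so this assay can respond to a single substituent exchange. However, it lies on a different aromatic ring and involves different groups. For the measured compounds named here, no measured compound varies the benzoyl ring, so the data give no firm direction for hydroxy there.

A small rise at most is expected, with no step beyond the scatter. The expected step is a 1.4-fold higher number from compound 2 to compound 4 (0.15 log units; within the scatter). For compound 4 the estimated value is 45 nM, with an expected range of 13 nM to 150 nM.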

Compound 4, half-maximal inhibitory concentration: 30 nM
The estimate for compound 4 lay 1.5-fold (0.18 log units) above the measured number; the measured number falls inside the stated range.
By their numbers in this assay, from the lowest: compound 1; then compounds 4 and 2 (each within the scatter of the next); then compound 3.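

Among these compounds, this is the first variation on the benzoyl ring, and in this assay hydroxy in place of hydrogen gives a 1.1-fold lower number from compound 2 to compound 4 (0.03 log units; within the scatter), which leaves the two numbers within the scatter of each other. So (3-hydroxyphenyl)carbonyl can stand in for benzoyl here, whereas the exchange on the other aromatic ring moved the number beyond the scatter (a 9.4-fold higher number from compound 2 to compound 3 (0.97 log units; beyond the scatter)). No measurement accompanies this result that could account for it.

Still open, on these data alone, is how an amine or a carboxylic acid on the benzoyl ring would read in this assay, and whether hydroxy elsewhere on that ring would match this result. Also open, as far as these compounds go, is whether the same hydroxy would stay within the scatter when paired with trifluoromethyl, as carried by compound 3, in place of methoxy.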